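This account rests on a few compounds, and the source may have more. Where it says the series, first, only, none or still open, it means among the compounds named here.

Measured so far in a physicochemical assay for solubility, measured as thermodynamic solubility, at pH 7.4; on this read-out lower numbers stand for lower solubility and higher numbers for higher solubility:
- compound 1 `O=C1NCCc2cc(C#Cc3ccccc3)ccc21`: 1000 nM
- compound 2 `O=C1CCOc2cc(OCc3cccc(Cl)c3)ccc21`: 1000 nM

In this assay compound 2 gives 1000 nM. Compound 1 gives 1000 nM. The two values agree at the digits reported and lie within the usual scatter of each other, so neither compound stands apart on these numbers.

Compound 3 `Cc1cccc(COc2ccc3c(c2)OCCC3=O)c1` has not yet been measured. It carries one change from compound 2: methyl in place of chloro on an aromatic carbon, meta to a large group (methyl in place of chloro on an aromatic carbon). Within the data shown here, the series holds no measured step between two compounds that differ in one place, so no swap of this kind has a size on record. Two values also give no ground for choosing a direction. The expectation therefore starts from compound 2 at 1000 nM, with no shift beyond the scatter in either direction. The estimated step is no change at the digits printed from compound 2 to compound 3 (within the scatter). For compound 3 the expected value in this assay is 1000 nM, with an estimated range of 400 nM to 2500 nM.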

Compound 3, solubility: 3000 nM
Beside the measured number, compound 3's estimate is 3.0-fold (0.48 log units) below it, outside the stated range (above it).
By their numbers in this assay, from the lowest: compounds 1 and 2 (each within the scatter of the next); then compound 3.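

In this assay, among these compounds, methyl in place of chloro on an aromatic carbon, meta to a large group, gives a 3.0-fold higher number from compound 2 to compound 3 (0.48 log units; beyond the scatter), a modest step beyond the scatter and the first measured step between compounds that differ in one place. The swap exchanges one heavy atom for one heavy atom, with no ring, hydrogen-bond donor, hydrogen-bond acceptor or net charge entering or leaving, so the read-out at this position can shift beyond the scatter with all of those counts unchanged. Nothing at hand bears on the reason for the shift.

As far as these compounds go, a single swap at a single position sets no trend, and whether a methoxy group, a nitrile or an amine at the same place would stand nearer to methyl or to chloro remains open. Also open, from the compounds shown here alone, is whether a step of this size would recur with the same swap at another carbon of that ring or on a different core.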